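The source may report more compounds than this note shows. Statements on the series, on what has been measured and on what is new or still open speak of the compounds shown alone.

Measured so far in a functional assay on the whole organism (strain Sprague-Dawley) for inhibition, with Rattus norvegicus as the target, with a stated time of 10 min; on this read-out lower numbers stand for an effect already at smaller amounts and higher numbers for an effect only at larger amounts of compound:
Compound 1 `CCOC(=O)c1cnc(-c2cc(Cl)ccc2OCC)[nH]c1=O` gives 0.5 mg/kg
Compound 2 `CCOC(=O)c1cnc(-c2cc(S(=O)(=O)N(C)C)ccc2OCC)[nH]c1=O` gives 50 mg/kg

Compound 2 holds the higher of the two numbers, with 50 mg/kg. Compound 3 `CCOC(=O)c1cnc(-c2cc(S(=O)(=O)N(CC)CC)ccc2OCC)[nH]c1=O` differs from it by diethylamino in place of dimethylamino on a sulfonyl sulfur, with diethylamino in place of dimethylamino on a sulfonyl sulfur. Within the data shown here, only one measured step bears on this, and only indirectly: a 100-fold higher number from compound 1 to compound 2 (2.00 log units; beyond the scatter), a large step in which dimethylsulfamoyl replaced chloro. Among the measured compounds shown here, no measured step changes the amino group on the sulfonyl sulfur, so no step beyond the scatter is expected in this assay. The expected step is no change at the digits printed from compound 2 to compound 3 (within the scatter). For compound 3 the estimated value is 50 mg/kg, with an expected range from 15 mg/kg to 170 mg/kg.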

Compound 3, dose for 50% inhibition: 10 mg/kg
Compound 3: middle estimate off by 5.0-fold (0.70 log units), on the high side; measured number below the stated range.
By their numbers in this assay, from the lowest: compound 1; then compound 3; then compound 2.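

In this assay the amino group on the sulfonyl sulfur proves able to shift the number: diethylamino in place of dimethylamino brings a 5.0-fold lower number from compound 2 to compound 3 (0.70 log units; beyond the scatter) as a modest step. Measured against the chloro group, the diethylsulfamoyl group still leaves a 20-fold higher number from compound 1 to compound 3 (1.30 log units; beyond the scatter) as a large step, so the change on the sulfur recovers only part of the loss seen with the sulfamoyl group. Nothing available gives a reason for either step.

From the compounds shown here alone, whether a longer chain such as dipropylamino, or a ring amine such as piperidine, on the sulfonyl sulfur would lower the number further stays open. So does whether bromo or trifluoromethyl in place of chloro would come near compound 1.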